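Changing the benzyl group and its effect on cell toxicity

The compounds below may be only part of what the source reports. "The series", "measured", "known", "first", "only" and "open" are said of these compounds alone.

In an ADME assay on RAW264.7 cells (Mus musculus) for cytotoxicity, read by MTT assay, with a stated time of 72 h, tested at 50 uM (on this read-out higher numbers stand for more inhibition at the one concentration tested (going by the name of the read-out) and lower numbers for less inhibition), compound 3 `CCOC(=O)c1sc(-c2ccncc2)nc1N1CCC(NCc2ccc(C(F)(F)F)cc2)CC1` gives 18.1%. Compound 2 `CCOC(=O)c1sc(-c2ccncc2)nc1N1CCC(NCc2ccc(OC)cc2)CC1` gives 16.1% and compound 1 `CCOC(=O)c1sc(-c2ccccc2)nc1N1CCC(NCc2ccc(Cl)cc2Cl)CC1` gives 9.43%, so all three numbers sit within the usual scatter of one another, and compound 3 cannot be set apart from either. Within the data shown here, the only measured step that touches the benzyl group is a number 2 percentage points higher from compound 2 to compound 3 (within the scatter). Compound 4 `CCOC(=O)c1sc(-c2ccncc2)nc1N1CCC(NCc2ccc(Cl)cc2Cl)CC1` differs from compound 3 by 2,4-dichlorophenyl in place of 4-(trifluoromethyl)phenyl on a saturated chain carbon bound to an amine nitrogen. Compound 1 carries the same 2,4-dichlorobenzyl group on a core of its own, and its value is close to that of compound 3. With that single step inside the scatter, the change is expected to give a number 5.1 percentage points lower from compound 3 to compound 4 (within the scatter), no shift beyond the scatter. Compound 4 is therefore estimated at 13%, between 3% and 24%.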

Compound 4, a percentage reported as inhibition, at one concentration (the size of the read-out at that concentration, not a potency): 18.4%
For compound 4 the middle estimate is 5.4 percentage points below the measured one; the range from low to high includes it.
By their numbers in this assay, from the lowest: compounds 1, 2, 3 and 4 (each within the scatter of the next).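

In this assay, 2,4-dichlorophenyl on a saturated chain carbon bound to an amine nitrogen gives a number 0.3 percentage points higher from compound 3 to compound 4 (within the scatter) and a number 2.3 percentage points higher from compound 2 to compound 4 (within the scatter), so these three benzyl groups on the shared core cannot be told apart at this position. The result also adds a step away from the benzyl group, pyridin-4-yl in place of phenyl, which gives a number 9 percentage points higher from compound 1 to compound 4 (within the scatter) and likewise no shift beyond the scatter. No supporting measurement is available to explain these numbers. Going by these compounds, whether a carboxylic acid or an amine on the benzyl ring, or a longer chain in place of the benzyl group, would move the number beyond the scatter stays open.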